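Hydrazone aryl variation on the triazolylpyridine urea series

The compounds below may be only part of what the source reports. "The series", "measured", "known", "first", "only" and "open" are said of these compounds alone.

Measured so far in a functional assay on HT-29 cells (Homo sapiens) for cytotoxicity, read by MTT assay, with a stated time of 72 h; on this read-out higher numbers stand for weaker inhibition and lower numbers for stronger inhibition:
- compound 1 `CN(C)CCn1cnnc1-c1cc(Oc2ccc(NC(=O)N/N=C/c3ccc(O)c(Br)c3)cc2F)ccn1`: 450 nM
- compound 2 `CN(C)CCn1cnnc1-c1cc(Oc2ccc(NC(=O)N/N=C/c3ccccc3O[N+](=O)[O-])cc2F)ccn1`: 950 nM
- compound 3 `CN(C)CCn1cnnc1-c1cc(Oc2ccc(NC(=O)N/N=C/c3ccc(F)cc3F)cc2F)ccn1`: 960 nM

Compound 2 stands second highest of the three numbers in this assay; its nearest neighbour is compound 3, a step of a 1.0-fold higher number from compound 2 to compound 3 (0.00 log units; within the scatter), and its furthest is compound 1, with a 2.1-fold higher number from compound 1 to compound 2 (0.32 log units; beyond the scatter) going the other way. The next compound, compound 4 `CN(C)CCn1cnnc1-c1cc(Oc2ccc(NC(=O)N/N=C/c3ccc(O)cc3O)cc2F)ccn1`, is not yet measured. It differs from compound 2 as follows: 2,4-dihydroxyphenyl in place of 2-(nitrooxy)phenyl on a carbon with a double bond to nitrogen.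

Among the compounds with values here, only one measured step involves a hydroxyl-bearing aryl group, namely a 2.1-fold higher number from compound 1 to compound 2 (0.32 log units; beyond the scatter), in which the group carrying the hydroxyl gave the lower number. The step from 2-(nitrooxy)phenyl to 2,4-difluorophenyl, a 1.0-fold higher number from compound 2 to compound 3 (0.00 log units; within the scatter), shows that not every change at this carbon moves the number. Within the data shown here, since compound 4 brings in two hydroxyls, a modest move toward a lower number is expected, roughly reversing a 2.1-fold higher number from compound 1 to compound 2 (0.32 log units; beyond the scatter), but with no direct precedent for a 2,4-dihydroxyphenyl the range is kept wide.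

Compound 4 is therefore estimated at 600 nM in this assay, between 300 nM and 1300 nM, an expected step of a 1.6-fold lower number from compound 2 to compound 4 (0.20 log units; within the scatter).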

Compound 4, half-maximal inhibitory concentration: 52600 nM
Estimate against measurement, compound 4: 88-fold (1.94 log units) below; the whole stated range lies below it.
By their numbers in this assay, from the lowest: compound 1; then compounds 2 and 3 (each within the scatter of the next); then compound 4.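

In this assay, within the data shown here, the aryl group on this carbon can move the number much further than the earlier compounds showed: bringing in 2,4-dihydroxyphenyl gives a 55-fold higher number from compound 2 to compound 4 (1.74 log units; beyond the scatter) and a 55-fold higher number from compound 3 to compound 4 (1.74 log units; beyond the scatter) in the two steps from the groups without a hydroxyl. A hydroxyl alone does not account for the change, as the step with a hydroxyl-bearing aryl group on both sides is the largest of the three, at a 120-fold higher number from compound 1 to compound 4 (2.07 log units; beyond the scatter) with compound 1 holding the lowest number of the series. No measurement at hand bears on the reason for this jump.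

The compounds shown do not separate the effect of the two hydroxyls from that of either one alone. On these data alone, whether methoxy groups or amino groups in place of those hydroxyls would keep the high number also remains open.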